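Fluorophenyl dienones: the trifluoromethyl step applied again

This account rests on a few compounds, and the source may have more. Where it says the series, first, only, none or still open, it means among the compounds named here.

Measured so far in a functional assay on PC-3 cells (Homo sapiens) for cytotoxicity, read by MTT assay, with a stated time of 72 h; a lower number here means a stronger inhibitor, a higher number a weaker inhibitor:
compound 1 `CC1=C(/C=C/C(=O)/C=C/c2ccccc2F)C(C)(C)CCC1O` gives 10400 nM
compound 2 `CC1=C(/C=C/C(=O)/C=C/c2cccc(F)c2)C(C)(C)CCC1O` gives 16000 nM
compound 3 `CC1=C(/C=C/C(=O)/C=C/c2cc(F)cc(C(F)(F)F)c2)C(C)(C)CCC1O` gives 3000 nM

Compounds 1 and 2 share the core and differ only in the aryl ring, (2-fluorophenyl in place of 3-fluorophenyl on a double-bonded chain carbon bound to a double-bonded chain carbon); the step of a 1.5-fold higher number from compound 1 to compound 2 (0.19 log units; within the scatter) is within the scatter, so the two are not separated here. From compound 2 to compound 3 a trifluoromethyl enters, (trifluoromethyl in place of hydrogen on an aromatic carbon), and this gives a 5.3-fold lower number from compound 2 to compound 3 (0.73 log units; beyond the scatter). The unmeasured compound 4 `CC1=C(/C=C/C(=O)/C=C/c2cc(C(F)(F)F)ccc2F)C(C)(C)CCC1O` carries the same kind of change made on compound 1, (trifluoromethyl in place of hydrogen on an aromatic carbon). The surroundings are not identical: in compound 3 the new group is meta to a fluoro group, in compound 4 it is para to a fluoro group. Among the measured compounds shown here, only one measured pair shows this change, so how much the surroundings matter is not known. Taking the step seen from compound 2 to compound 3 as the guide, the expected step for compound 4 is a 4.2-fold lower number from compound 1 to compound 4 (0.62 log units; beyond the scatter). Compound 4 is therefore estimated at 2500 nM in this assay. The range expected for compound 4 runs from 900 nM to 7000 nM.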

Compound 4, half-maximal inhibitory concentration: 3600 nM
Compound 4: middle estimate off by 1.4-fold (0.16 log units), on the low side; measured number inside the range.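

In this assay the trifluoromethyl change made on the core of compound 1 gives a 2.9-fold lower number from compound 1 to compound 4 (0.46 log units; beyond the scatter), so the lower number seen with the earlier pair appears again on a second fluorophenyl series member. Set side by side, the two steps cannot be told apart: the same change on two cores in this assay, a 5.3-fold lower number (0.73 log units; beyond the scatter) from compound 2 to compound 3 and a 2.9-fold lower number (0.46 log units; beyond the scatter) from compound 1 to compound 4, 1.8-fold (0.27 log units) apart, within the scatter of two such steps. This shows that the change carried over in direction and, within the scatter, in size across these two pairs, but two pairs with different surroundings around the new group do not measure how much those surroundings matter, nor do they show that the step would hold on other aryl patterns.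

Still open, on these data alone, is whether a nitrile, a methoxy group or a chlorine atom in place of the trifluoromethyl would give a step of similar size in this assay. Also open, as far as these compounds go, is whether the step survives when the hydroxyl group of the shared core gives way to a ketone or an amine.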